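Bulkier Nitrogen Substituent on a Thiophene Amide Series

The source may hold more compounds than are shown below. What is called first, only, known or untested is meant among the compounds shown, and "the series" means these compounds.

Of the compounds shown here, three from one series have been measured in an assay on HEK293 cells for agonist activity at transient receptor potential cation channel subfamily M member 8 (Homo sapiens), read by fluorescence and calcium flux, with a stated time of 15 min; on this read-out lower numbers stand for an effect already at smaller amounts and higher numbers for an effect only at larger amounts of compound. Compound 1 `CCN(Cc1cccs1)C(=O)COc1ccc(Cl)cc1` gives 39 nM in this assay. Compound 3 `CCN(Cc1cccs1)C(=O)CCc1ccc(C)cc1` gives 93 nM. Compound 2 `Cc1ccc(OCC(=O)N(C)Cc2cccs2)cc1` gives 400 nM, which is the highest of the three numbers: compound 3 sits closest to it with a number that is lower beyond the scatter, and compound 1 is furthest away, also beyond the scatter. Among these three, compound 2 thus shows the weakest response.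

Compound 4 `Cc1ccc(OCC(=O)N(Cc2cccs2)C(C)(C)C)cc1` has not yet been measured in this assay. It differs from compound 2 in one place, (tert-butyl in place of methyl on an amide-type nitrogen). Among the compounds with values here, no pair of measured compounds shares this particular change, so no measured step speaks for it directly. Within the data shown here, the only guidance is that compound 2, with the smaller group on its amide-type nitrogen, shows the highest number in the set, while compound 1 at 39 nM and compound 3 at 93 nM carry other substitution and give lower numbers.

The expected step for this change is a 1.8-fold lower number from compound 2 to compound 4 (0.26 log units; within the scatter), a modest lowering that may not clear the scatter. Compound 4 is accordingly estimated at 220 nM, with a plausible range from 60 nM to 800 nM.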

Compound 4, half-maximal effective concentration: 11000 nM
Estimate against measurement, compound 4: 50-fold (1.70 log units) below, and the stated range ends below it.
By their numbers in this assay, from the lowest: compound 1; then compound 3; then compound 2; then compound 4.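

Within the data shown here, replacing methyl with tert-butyl on the amide-type nitrogen produces a 28-fold higher number from compound 2 to compound 4 (1.44 log units; beyond the scatter) in this assay, so this position proves highly sensitive to the group it carries, which the earlier compounds could not show. The change itself is simple on paper: 1 heavy atom gives way to 4 heavy atoms, all carbon, with no ring, hydrogen-bond donor, hydrogen-bond acceptor or net charge entering or leaving, yet this single exchange moves the number far beyond the scatter and in the opposite direction to the modest lowering that had been expected. No data shown here on the properties of these groups or on how the compounds act at the receptor bear on why the step is so large.

With only methyl and tert-butyl compared directly on this nitrogen, the compounds leave open whether the number rises gradually or abruptly between these two groups, which an isopropyl or a cyclopropyl group at the same place would help to settle. Also open, as far as these compounds go, is whether tert-butyl on this nitrogen would produce a step of similar size on the core of compound 1 or compound 3.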